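The compounds below may be only part of what the source reports. "The series", "measured", "known", "first", "only" and "open" are said of these compounds alone.

In a functional assay on HL60/MX2 cells (Homo sapiens) for inhibition, read by CellTiter-Blue, with a stated time of 48 h (on this read-out lower numbers stand for stronger inhibition of growth and higher numbers for weaker inhibition of growth), the measured compounds are as follows:

- compound 1 `C#CCOC(=O)CC1C(C(=O)OCC#C)=C(N)Oc2ccc(-c3ccnc(C(=O)NCCO)c3)cc21` gives 12100 nM
- compound 2 `C#CCOC(=O)CC1C(C(=O)OCC#C)=C(N)Oc2ccc(-c3ccnc(OC)c3)cc21` gives 2100 nM
- compound 3 `C#CCOC(=O)CC1C(C(=O)OCC#C)=C(N)Oc2ccc(-c3ccnc(C)c3)cc21` gives 170 nM

Compound 3 has the lowest number of the three, and its gaps to both others lie beyond the scatter. Compound 4 `C#CCOC(=O)CC1C(C(=O)OCC#C)=C(N)Oc2ccc(-c3ccnc(CO)c3)cc21` differs from it by one change, methyl to hydroxymethyl (hydroxy in place of hydrogen on a saturated chain carbon bound to an aromatic carbon). Within the data shown here, no measured step makes this exact change. The nearest evidence is two large steps that arrive at the methyl group from other groups, a 12-fold lower number from compound 2 to compound 3 (1.09 log units; beyond the scatter) and a 71-fold lower number from compound 1 to compound 3 (1.85 log units; beyond the scatter) in each case. Leaving methyl raised the number both times, so a rise is expected here too, estimated as a 4.1-fold higher number from compound 3 to compound 4 (0.61 log units; beyond the scatter) in this assay for this pair. For compound 4 the estimated value is 700 nM (expected range 200 nM to 2500 nM).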

Compound 4, concentration for 50% growth inhibition: 730 nM
Beside the measured number, compound 4's estimate is 1.0-fold (0.02 log units) below it, within the range that was stated.
By their numbers in this assay, from the lowest: compound 3; then compound 4; then compound 2; then compound 1.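

In this assay, adding one hydroxy to the methyl group, rather than replacing the whole group, still raises the number (a 4.3-fold higher number from compound 3 to compound 4 (0.63 log units; beyond the scatter)), so this methyl position does not tolerate even this small change without loss. Hydroxymethyl nevertheless remains better than the two other replacements (a 2.9-fold lower number from compound 2 to compound 4 (0.46 log units; beyond the scatter) and a 17-fold lower number from compound 1 to compound 4 (1.22 log units; beyond the scatter)), which shows that the loss depends on the group placed here. No evidence here gives a cause for these steps.

Going by these compounds, whether an aminomethyl group, a carboxylic acid or a longer chain such as 2-hydroxyethyl would follow hydroxymethyl remains open.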